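Chain homologues on a shared triaryl core

The source may report more compounds than this note shows. Statements on the series, on what has been measured and on what is new or still open speak of the compounds shown alone.

Measured compounds:
compound 1 `O=C(O)CCCCCn1nc(-c2ccccc2)c(-c2ccccc2)c1-c1ccccc1` gives > 78000 nM in a functional assay for inhibition, with Homo sapiens as the target (on this read-out lower numbers stand for stronger inhibition and higher numbers for weaker inhibition), a limit of the assay
compound 2 `O=C(O)CCCCCCn1nc(-c2ccccc2)c(-c2ccccc2)c1-c1ccccc1` gives 22400 nM in this assay
compound 3 `O=C(O)CCCCCCCCn1nc(-c2ccccc2)c(-c2ccccc2)c1-c1ccccc1` gives 400 nM in this assay

The value of compound 1 is only a limit of this assay and not a number (the limit of > 78000 nM in this assay, at which 1 of the 3 values shown sits). Compound 2 sits at a number, and the step of an at least 3.4-fold lower number from compound 1 to compound 2 (0.54 log units; beyond the scatter) corresponds to carboxymethyl in place of carboxy on a saturated chain carbon, five bonds along the chain from an aromatic nitrogen. Compound 3 holds the lowest of the two numbers, with a 56-fold lower number from compound 2 to compound 3 (1.75 log units; beyond the scatter) and an at least 190-fold lower number from compound 1 to compound 3 (2.29 log units; beyond the scatter); the latter corresponds to 3-carboxypropyl in place of carboxy on a saturated chain carbon, five bonds along the chain from an aromatic nitrogen. Among the three measured compounds every lengthening of the chain lowers the number, and none goes against this.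

Compound 4 `O=C(O)CCCCCCCCCn1nc(-c2ccccc2)c(-c2ccccc2)c1-c1ccccc1` is not yet measured. It differs from compound 3 by carboxymethyl in place of carboxy on a saturated chain carbon, eight bonds along the chain from an aromatic nitrogen. This is the same kind of change as from compound 1 to compound 2, but the place differs: there five bonds along the chain from an aromatic nitrogen, here eight bonds along the chain from an aromatic nitrogen. Given a 56-fold lower number from compound 2 to compound 3 (1.75 log units; beyond the scatter), which spans a longer extension, a step of a 2.7-fold lower number from compound 3 to compound 4 (0.43 log units; beyond the scatter) is expected for compound 4 in this assay. Compound 4 is thus estimated at 150 nM, expected between 40 nM and 500 nM.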

Compound 4, half-maximal inhibitory concentration: 5500 nM
Estimate against measurement, compound 4: 37-fold (1.56 log units) below; measured number outside the range, above it.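

Carboxymethyl in place of carboxy does not carry over from one chain length to another in this series: the same change on two cores in this assay, an at least 3.4-fold lower number (0.54 log units; beyond the scatter) from compound 1 to compound 2 and a 14-fold higher number (1.14 log units; beyond the scatter) from compound 3 to compound 4, at least 47-fold (1.68 log units) apart, beyond the scatter of two such steps Compound 4 goes against the fall seen across the three shorter homologues, with a 14-fold higher number from compound 3 to compound 4 (1.14 log units; beyond the scatter), although the number stays lower than for the shorter chains, with a 4.1-fold lower number from compound 2 to compound 4 (0.61 log units; beyond the scatter) and an at least 14-fold lower number from compound 1 to compound 4 (1.15 log units; beyond the scatter). The same one-carbon extension can therefore lower or raise the number depending on the chain it is made on, but these results do not show why, nor whether this holds on a different core.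

The value of compound 1 is a limit of this assay and not a number: the limit of > 78000 nM in this assay, at which 1 of the 4 values shown sits. Open are a longer chain than that of compound 4, which would show whether the number keeps rising, and an amide in place of the carboxylic acid at the end of the chain.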